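Methoxy count on the aryl ring and cell tolerance

The compounds below may be only part of what the source reports. "The series", "measured", "known", "first", "only" and "open" are said of these compounds alone.

Working notes on the cinnamoyl-aniline pyrazoles. Compound 1 `COc1ccc(-c2cc(/C=C/C(=O)c3ccc(N)cc3)[nH]n2)cc1` carries a single methoxy group; in a functional assay on CCRF-CEM cells (Homo sapiens) for inhibition, read by sulforhodamine B assay, with a stated time of 48 h (a higher number here means that more compound is tolerated, a lower number that less compound is tolerated), compound 1 gives 36100 nM. Compound 2 `COc1cc(-c2cc(/C=C/C(=O)c3ccc(N)cc3)[nH]n2)cc(OC)c1OC` carries three methoxy groups. In this assay compound 2 stands only at a limit, > 100000 nM, which is a boundary of the measurement rather than a number; it is the one case of the limit of > 100000 nM in this assay, at which 1 of the 2 values shown sits, among the two values shown. Compound 3 `COc1ccc(-c2cc(/C=C/C(=O)c3ccc(N)cc3)[nH]n2)cc1OC` is the not yet measured member. It differs from compound 2 by hydrogen in place of methoxy on an aromatic carbon, ortho to a methoxy group and meta to a methoxy group. The expected step from compound 2 to compound 3 is an at least 1.6-fold lower number from compound 2 to compound 3 (0.22 log units; that floor lies within the scatter), downward toward the value of compound 1, but of uncertain size. Compound 3 is estimated at 60000 nM, with a range from 25000 nM to 150000 nM, a limit result remaining possible.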

Compound 3, concentration lethal to 50% of the cells: > 100000 nM
Compound 3: a limit, no number (the forecaster's own chance of this, stated with the estimate: 35%); middle value at least 1.6-fold (0.22 log units) from the limit.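

In this assay, methoxy in place of hydrogen on an aromatic carbon, ortho to a methoxy group, gives an at least 2.7-fold higher number from compound 1 to compound 3 (0.44 log units; beyond the scatter), so a second methoxy group on the aryl ring is already enough to give a higher number. The step between compound 2 and compound 3 cannot be read, because both stand at the same limit: the limit of > 100000 nM in this assay, at which 2 of the 3 values shown sit.

Any further change from the third methoxy group therefore stays out of view, and the series shows a clear step only for the addition of the second methoxy group.

The compounds shown leave open how far beyond the limit compound 2 and compound 3 truly lie. Also open, going by these compounds, is whether the step belongs to methoxy itself or would also follow from another group at this position, such as a hydroxyl group or a chlorine atom.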